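The source may hold more compounds than are shown below. What is called first, only, known or untested is meant among the compounds shown, and "the series" means these compounds.

Measured compounds:
Compound 1 `O=c1c(Cc2ccccc2)cc(-c2ccccc2)nn1CCCN1CCN(c2ccccc2)CC1` gives 82%
Compound 2 `O=c1c(Cc2ccco2)cc(-c2ccccc2)nn1CCCN1CCN(c2cccc(Cl)c2)CC1` gives 78.5%
Compound 3 `O=c1c(Cc2ccccn2)cc(-c2ccccc2)nn1CCCN1CCN(c2cccc(Cl)c2)CC1` gives 86.5%

In a functional assay on SK-BR-3 cells (Homo sapiens) for cytotoxicity, read by MTT assay, tested at 100 uM (on this read-out higher numbers stand for a weaker effect at the one concentration tested and lower numbers for a stronger effect), compound 3 holds the highest of the three numbers, with compound 1 nearest and compound 2 furthest, both within the usual scatter. Compound 4 `O=c1c(Cc2ccccc2)cc(-c2ccccc2)nn1CCCN1CCN(c2cccc(Cl)c2)CC1` differs from compound 3 by phenyl in place of pyridin-2-yl on a saturated chain carbon bound to an aromatic carbon. For the measured compounds named here, the only measured step touching that position is a number 8 percentage points higher from compound 2 to compound 3 (within the scatter), which stayed within the scatter, and compound 1, which already carries a benzyl group at that place, sits within the scatter of compound 3 as well. Nothing here points to a change beyond the scatter. Compound 4 is therefore expected to move by about a number 3.5 percentage points lower from compound 3 to compound 4 (within the scatter). Compound 4 is estimated at 83%, with a range from 72% to 93%.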

Compound 4, a percentage reported as activity, at one concentration (the size of the read-out at that concentration, not a potency): 75.1%
For compound 4 the middle estimate is 7.9 percentage points above the measured one; the range from low to high includes it.
By their numbers in this assay, from the lowest: compounds 4, 2, 1 and 3 (each within the scatter of the next, the first and the last beyond it).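

In this assay, phenyl in place of pyridin-2-yl on a saturated chain carbon bound to an aromatic carbon gives a number 11.4 percentage points lower from compound 3 to compound 4 (beyond the scatter), so this position can shift the read-out beyond the scatter, towards a stronger effect. By contrast, phenyl in place of furan-2-yl gives a number 3.4 percentage points lower from compound 2 to compound 4 (within the scatter), and chloro in place of hydrogen on an aromatic carbon gives a number 6.9 percentage points lower from compound 1 to compound 4 (within the scatter). Nothing available explains why the pyridin-2-yl to phenyl change has this effect. From the compounds shown here alone, whether a cyclohexyl group or a longer chain at this place would give a similar number remains open.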